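A Dichlorophenyl Swap on the Shared Core

This account rests on a few compounds, and the source may have more. Where it says the series, first, only, none or still open, it means among the compounds named here.

Compound 1 `CC(=O)Nc1ccc(S(=O)(=O)NNC(=O)c2cccnc2Nc2ccc(Cl)cc2)cc1` was tested in a functional assay on M14 cells (Homo sapiens) for antiproliferative activity (on this read-out lower numbers stand for stronger inhibition of growth and higher numbers for weaker inhibition of growth), where it gave only the limit of the assay, > 100000 nM. Compound 2 `O=C(NNS(=O)(=O)c1ccc(F)cc1)c1cccnc1Nc1ccc(Cl)cc1Cl` likewise gave only a limit in this assay, > 100000 nM. Compound 1 thus stands where every value shown stands (the limit of > 100000 nM in this assay, at which 2 of the 2 values shown sit). Compound 3 `O=C(NNS(=O)(=O)c1ccc(Cl)cc1Cl)c1cccnc1Nc1ccc(Cl)cc1` differs from compound 1 in one place: 2,4-dichlorophenyl in place of 4-acetamidophenyl on a sulfonyl sulfur. Going by the values given here, with no measured step of this kind, the expected step from compound 1 to compound 3, a number no higher from compound 1 to compound 3 (the limit leaves the size open), is none beyond the scatter. Compound 3 is therefore estimated at 100000 nM, within 30000 nM to 300000 nM, most likely reported again as a limit.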

Compound 3, concentration for total growth inhibition: 38900 nM
Compound 3: the middle estimate sits 2.6-fold (0.41 log units) above what was measured; measured number inside the range.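

In this assay, 2,4-dichlorophenyl in place of 4-acetamidophenyl on a sulfonyl sulfur gives an at least 2.5-fold lower number from compound 1 to compound 3 (0.41 log units; beyond the scatter). Going by these compounds alone, compound 3 is the first compound here with a number rather than a limit, which shows that a change at this position alone can move the read-out on the shared core. Most values still remain at the limit: the limit of > 100000 nM in this assay, at which 2 of the 3 values shown sit.

On these data alone, whether one chlorine alone would give the same step stays open. So does the outcome with an amine or a carboxylic acid on this phenyl ring.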